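The source may hold more compounds than are shown below. What is called first, only, known or untested is meant among the compounds shown, and "the series" means these compounds.

Measured compounds in a functional assay on PC-9 cells (Homo sapiens) for inhibition, read by MTT assay, with a stated time of 48 h, tested at 10 uM; a lower number here means less inhibition, a higher number more inhibition at the concentration tested (going by the name of the read-out):
compound 1 `Cc1ccc(Nc2cc(NC(=O)Nc3c(Cl)cccc3Cl)ncn2)cc1F` gives 92%
compound 2 `CCc1ccc(Nc2cc(NC(=O)Nc3cc(OC)cc(OC)c3)ncn2)cc1` gives 78%
compound 3 `COc1cc(NC(=O)Nc2cc(Nc3ccc(C)c(F)c3)ncn2)cc(OC)c1` gives 77.5%

Compound 1 stands highest of the three numbers in this assay; compound 2 and compound 3 each sit lower by a gap beyond the scatter. Going by the values given here, the single measured step, a number 0.5 percentage points lower from compound 2 to compound 3 (within the scatter), exchanges the group on the same nitrogen and stays within the scatter; it is the only step that bears on the change at hand.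

Compound 4 `COc1ccc(Br)cc1Nc1cc(NC(=O)Nc2c(Cl)cccc2Cl)ncn1` differs from compound 1 by 5-bromo-2-methoxyphenyl in place of 3-fluoro-4-methylphenyl on a nitrogen on an aromatic ring. Among the compounds with values here, the entering group appears in no measured compound, so the sole guide is the step on this nitrogen, which showed nothing beyond the scatter. The step of a number 7 percentage points lower from compound 1 to compound 4 (within the scatter) is therefore expected to be small, if anything slightly downward given how high compound 1 already reads. Compound 4 is estimated at 85% in this assay, with a range from 65% to 97%.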

Compound 4, a percentage reported as inhibition, at one concentration (the size of the read-out at that concentration, not a potency): 69%
Estimate against measurement, compound 4: 16 percentage points above; low and high end bracket the measured number.
By their numbers in this assay, from the lowest: compounds 4, 3 and 2 (each within the scatter of the next); then compound 1.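

In this assay the group on this nitrogen can move the read-out: the change to 5-bromo-2-methoxyphenyl gives a number 23 percentage points lower from compound 1 to compound 4 (beyond the scatter) while the earlier exchange at the same place, made in a different compound pair, gave a number 0.5 percentage points lower from compound 2 to compound 3 (within the scatter) and so showed no such response. The position is therefore not indifferent to its group. Nothing at hand explains the drop.

Still open, as far as these compounds go, is whether the bromine or the methoxy of the entering group accounts for the step. From the compounds shown here alone, how a carboxylic acid or an amine on this phenyl ring would read also remains open.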